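A few compounds are considered here, and "the series" means these few. Any claim that something is new, unique, unknown or untested is made for them only; others in the source may bear on it.

Measured so far:
- compound 1, `Cn1nnnc1SCC(=O)N/N=C/c1ccccc1[N+](=O)[O-]`, 2020000 nM in an ADME assay on NIH3T3 cells (Mus musculus) for cytotoxicity, read by XTT assay, with a stated time of 24 h; on this read-out lower numbers stand for stronger inhibition and higher numbers for weaker inhibition
- compound 2, `Cn1nnnc1SCC(=O)N/N=C/c1ccccc1F`, 2000000 nM in this assay
- compound 3, `Cn1nnnc1SCC(=O)N/N=C/c1ccccc1Br`, 20000 nM in this assay

Compound 3 stands lowest of the three numbers, that is, it inhibits the cells most strongly. Its nearest neighbour on the numbers is compound 2, and the gap between them is large: a 100-fold lower number from compound 2 to compound 3 (2.00 log units; beyond the scatter). The gap to compound 1 is of the same size: a 100-fold lower number from compound 1 to compound 3 (2.00 log units; beyond the scatter). Compounds 1 and 2 themselves sit together, a 1.0-fold lower number from compound 1 to compound 2 (0.00 log units; within the scatter).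

The unmeasured compound 4, `Cn1nnnc1SCC(=O)N/N=C/c1ccccc1O`, differs from compound 3 in one place: hydroxy in place of bromo on an aromatic carbon. So the group that sets compound 3 apart from the other two is removed, and a small group with a hydrogen-bond donor and acceptor takes its place on the shared core. Both measured steps that bear on this position, from compound 1 and from compound 2 to compound 3, show that only bromo came with the strongly lower number, while nitro and fluoro gave values close to each other. A hydroxy group has not been seen here, so its effect is not known from these data; the most defensible expectation is that compound 4 returns toward the values of compounds 1 and 2, a large step upward, estimated as a 75-fold higher number from compound 3 to compound 4 (1.88 log units; beyond the scatter).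

Compound 4 is therefore expected to give about 1500000 nM in this assay, with a likely range from 200000 nM to 5000000 nM.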

Compound 4, half-maximal inhibitory concentration: > 10000000 nM
Compound 4: a limit, no number (the forecaster's own chance of this, stated with the estimate: 20%); middle value at least 6.6-fold (0.82 log units) from the limit.
By their numbers in this assay, from the lowest: compound 3; then compounds 2 and 1 (each within the scatter of the next). At a limit, above all of these: compound 4.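

In this assay, this position separates three levels rather than two. Hydroxy in place of bromo gives an at least 500-fold higher number from compound 3 to compound 4 (2.69 log units; beyond the scatter), while hydroxy also stands apart from the two groups that had shown no difference from each other, with an at least 5.0-fold higher number from compound 2 to compound 4 (0.69 log units; beyond the scatter) and an at least 4.9-fold higher number from compound 1 to compound 4 (0.69 log units; beyond the scatter). The earlier compounds shown here could show only that bromo stood apart from nitro and fluoro, whereas this change shows that another single-atom swap at the same place, one that adds a hydrogen-bond donor and a hydrogen-bond acceptor, moves the number upward beyond the scatter from all three. The value of compound 4 is a limit of the assay and not a number, so each of these steps gives only a minimum size: the limit of > 10000000 nM in this assay, at which 1 of the 4 values shown sits.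

On these data alone, whether chloro or iodo in this place would stay close to bromo or move toward nitro and fluoro remains open, and so does the result for methoxy, which would keep the oxygen of hydroxy but replace its hydrogen with a methyl group. As far as these compounds go, how far compound 4 lies beyond its limit also remains open, so the full size of its steps cannot be read.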